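This account rests on a few compounds, and the source may have more. Where it says the series, first, only, none or still open, it means among the compounds named here.

Among the compounds with values here, compound 2 `Nc1scc(CN2CCN(c3ccccc3C(F)(F)F)CC2)c1C(=O)c1ccc(Cl)cc1` is one of three compounds measured in a functional assay on CHO cells with adenosine receptor A1 (Homo sapiens) as the target, read by cAMP accumulation and immunoassay, with a stated time of 6 min, tested at 10 uM; on this read-out higher numbers stand for a weaker effect at the one concentration tested and lower numbers for a stronger effect. In this assay compound 2 gives -60%. Its nearest neighbour on the numbers is compound 1 `Nc1scc(CN2CCN(c3cccc(C(F)(F)F)c3)CC2)c1C(=O)c1ccc(Cl)cc1`, which gives -80%; the step of a number 20 percentage points higher from compound 1 to compound 2 (beyond the scatter) lies beyond the scatter, so compound 2 stands second highest of the three. Within the data shown here, the furthest is compound 3 `Nc1scc(CN2CCN(c3c(F)cccc3F)CC2)c1C(=O)c1cccc(C(F)(F)F)c1`, which gives 4%, a clearly higher number; compound 3 differs from compound 2 in more than one place, so no single step connects them.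

Compound 4 `Nc1scc(CN2CCN(c3cccc4ccccc34)CC2)c1C(=O)c1ccc(Cl)cc1` has not yet been measured in this assay. It differs from compound 2 in one place: naphthalen-1-yl in place of 2-(trifluoromethyl)phenyl on an amine nitrogen in a ring. Among the measured compounds shown here, the only measured step at the same amine nitrogen in a ring is the one from compound 1 to compound 2, where 2-(trifluoromethyl)phenyl replaced 3-(trifluoromethyl)phenyl and gave a number 20 percentage points higher from compound 1 to compound 2 (beyond the scatter), a modest shift beyond the scatter. For the measured compounds named here, no measured step exchanges a phenyl ring for naphthalen-1-yl, so the direction for compound 4 is not fixed by the data. Both aryl groups tried on that nitrogen in compounds 1 and 2 gave strongly negative numbers. Compound 4 is therefore expected to remain in that region, with a step of a number 5 percentage points higher from compound 2 to compound 4 (within the scatter) expected to be within or only slightly beyond the scatter. The estimate for compound 4 is -55%, with a range from -85% to -15%.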

Compound 4, a percentage reported as activity, at one concentration (the size of the read-out at that concentration, not a potency): -21%
The estimate for compound 4 lay 34 percentage points below the measured number; the range from low to high includes it.
By their numbers in this assay, from the lowest: compound 1; then compound 2; then compound 4; then compound 3.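

In this assay, the aryl group on the amine nitrogen proves able to move the number much further than the earlier trifluoromethyl shift did: naphthalen-1-yl gives a number 39 percentage points higher from compound 2 to compound 4 (beyond the scatter) and a number 59 percentage points higher from compound 1 to compound 4 (beyond the scatter), both large steps, whereas the step of a number 20 percentage points higher from compound 1 to compound 2 (beyond the scatter) was only modest. The group that leaves and the group that enters each hold 10 heavy atoms and neither has a hydrogen-bond donor or acceptor, so this position responds to a change that leaves those counts untouched, although compound 4 at -21% stays negative, as the two trifluoromethyl compounds do. No available evidence accounts for the size of these steps.

The compounds shown do not separate the loss of the trifluoromethyl group from the gain of a second aromatic ring, and a plain phenyl ring or a pyridine ring on the same nitrogen would bear on that question. They also leave open whether naphthalen-1-yl would give a similar step on a core that carries a different aryl ketone.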